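Two measured analogues and one unmeasured change on the carbonyl

This account rests on a few compounds, and the source may have more. Where it says the series, first, only, none or still open, it means among the compounds named here.

Compound 1, `COc1cc(/C(Cl)=C/C=C(\C#N)C(=O)c2c[nH]c3ccc(Br)cc23)cc(OC)c1OC`, in an ADME assay on Vero cells (Chlorocebus sabaeus) for cytotoxicity, read by sulforhodamine B assay, with a stated time of 48 h (on this read-out higher numbers stand for weaker inhibition of growth and lower numbers for stronger inhibition of growth), gives 7600 nM.
Compound 2, `COc1ccc(/C(Cl)=C/C=C(\C#N)C(=O)c2c[nH]c3ccc(Br)cc23)cc1OC`, in this assay gives 8200 nM.

Among the compounds with values here, compound 1 stands together with compound 2 in this assay, the only measured step, a 1.1-fold higher number from compound 1 to compound 2 (0.03 log units; within the scatter), being hydrogen in place of methoxy on an aromatic carbon. Compound 3, `COc1cc(/C(Cl)=C/C=C(\C#N)C(=O)c2c(C)[nH]c3ccccc23)cc(OC)c1OC`, differs from compound 1 by 2-methyl-1H-indol-3-yl in place of 5-bromo-1H-indol-3-yl on a carbonyl carbon. No measured step touches the group on the carbonyl carbon, so the data give no guide for it; the one step shown lies elsewhere and is within the scatter. Compound 3 is therefore expected to show no step beyond the scatter in this assay, the estimated step being a 1.1-fold higher number from compound 1 to compound 3 (0.02 log units; within the scatter). Compound 3 is estimated at 8000 nM, between 2500 nM and 25000 nM.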

Compound 3, concentration for 50% growth inhibition: 12400 nM
Compound 3: middle estimate off by 1.6-fold (0.19 log units), on the low side; low and high end bracket the measured number.
By their numbers in this assay, from the lowest: compounds 1, 2 and 3 (each within the scatter of the next).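

In this assay, within the data shown here, the group on the carbonyl carbon can now be read for the first time: 2-methyl-1H-indol-3-yl in place of 5-bromo-1H-indol-3-yl gives a 1.6-fold higher number from compound 1 to compound 3 (0.21 log units; within the scatter), so this exchange stays within the scatter. Among these compounds, the one step at this position thus resembles the methoxy step elsewhere on the molecule. Nothing at hand accounts for this result. Going by these compounds, because bromine and methyl are exchanged together, their separate contributions remain open. So does the read-out with an indol-3-yl group carrying an amine or a carboxylic acid.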